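The source may hold more compounds than are shown below. What is called first, only, known or untested is meant among the compounds shown, and "the series" means these compounds.

Measured so far in the series:

- compound 1, `COc1ccc(NCc2nc3ccccc3[nH]2)cc1`: 29.4% in a functional assay on the whole organism (strain albino) for inhibition, with Rattus norvegicus as the target, read by paw edema, with a stated time of 120 min, at a dose of 100 mg/kg by the oral route; on this read-out lower numbers stand for less inhibition and higher numbers for more inhibition at the one dose given (going by the name of the read-out)
- compound 2, `O=[N+]([O-])c1ccc2nc(CNc3ccc(Br)cc3)[nH]c2c1`: 23.5% in this assay

Compound 2 stands lowest of the two numbers in this assay. Its nearest neighbour is compound 1, whose number is higher by an amount that lies within the scatter of repeated measurements, so the two compounds are not told apart by this read-out.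

Compound 3, `Brc1ccc(NCc2nc3ccccc3[nH]2)cc1`, has not yet been measured in this assay. Against compound 2 it differs by hydrogen in place of nitro on an aromatic carbon. Among the compounds with values here, no step between two measured compounds isolates this change: compound 1 also lacks the nitro group, but it carries methoxy where compound 3 carries bromine, so the value of compound 1 is only a loose guide. Within the data shown here, with no measured step to lean on, the step expected in this assay from loss of the nitro group is small, if any, and not clearly beyond the scatter in either direction.

The estimate for compound 3 in this assay is 27%, with a range from 15% to 40%. The expected step is a number 3.5 percentage points higher from compound 2 to compound 3 (within the scatter).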

Compound 3, a percentage reported as inhibition, in the whole organism at one dose (the size of the read-out at that dose, not a potency): 23.5%
The estimate for compound 3 lay 3.5 percentage points above the measured number; the measured number falls inside the stated range.
By their numbers in this assay, from the lowest: compounds 2, 3 and 1 (each within the scatter of the next).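

Working notes on the series: in this assay, hydrogen in place of nitro on an aromatic carbon of the fused system gives no change at the digits printed from compound 2 to compound 3 (within the scatter), the first step in the series that isolates this place, and the read-out does not register the presence of the nitro group with a bromo substituent held constant. Bromo in place of methoxy on an aromatic carbon gives a number 5.9 percentage points lower from compound 1 to compound 3 (within the scatter), so this second single change also leaves the compounds unseparated, and the three compounds form one group at the single oral dose. No measurement at hand bears on the reason for these numbers.

Going by these compounds, both steps come from a single substituent each, so it remains open whether a different group on the same aromatic carbon of the fused system, such as an amine or a carboxylic acid, would give a step beyond the scatter. Also open, on these data alone, is whether a longer chain in place of the methylene link, or a carboxylic acid in place of the bromo substituent, would separate any compound from this group.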